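This account rests on a few compounds, and the source may have more. Where it says the series, first, only, none or still open, it means among the compounds named here.

Working notes on the series, read in a functional assay on HCT-116 cells (Homo sapiens) for cytotoxicity, read by MTT assay, with a stated time of 72 h; a lower number here means a stronger inhibitor, a higher number a weaker inhibitor. For compound 1 (`O=C(NCc1ccc(F)cc1)c1nc(NCCO)c2cccnc2c1O`) the entry is "not determined" (no result reported). Compound 2 (`Nc1cccc(Nc2c(C(=O)NCc3ccc(F)cc3)nc(Br)c3cccnc23)c1`) gives > 10000 nM, which is a limit of the assay and not a number. Among the measured compounds shown here, compound 3 (`N[C@H]1CC[C@H](Nc2c(C(=O)NCc3ccc(F)cc3)nc(N3CCCCC3)c3cccnc23)CC1`) gives 8500 nM, the only true number so far. Compound 4 (`C[C@H](Nc1c(C(=O)NCc2ccc(F)cc2)nc(Br)c2cccnc12)c1ccccc1`) differs from compound 2 as follows: 1-phenylethyl in place of 3-aminophenyl on a nitrogen on an aromatic ring. In words, 1-phenylethyl stands in place of 3-aminophenyl on a nitrogen on an aromatic ring. For the measured compounds named here, no measured pair shows this change, so no shift beyond the scatter is expected, in either direction. The expected step is a step that the limit leaves unreadable from compound 2 to compound 4. Compound 4 is estimated at 12000 nM, with an expected range of 4000 nM to 30000 nM.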

Compound 4, half-maximal inhibitory concentration: > 20000 nM
Compound 4: no number, only a limit; the forecaster's own chance of this, stated with the estimate: 55%; at least 1.6-fold (0.22 log units) between middle value and limit.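

Among the compounds shown here, compound 2 and compound 4 both stand at limits of the assay and not at numbers, so no step between them can be read. The compounds shown leave open how 1-phenylethyl and 3-aminophenyl on that nitrogen actually compare.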